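One Inverted Stereocentre in a Series at the Limit

The source may report more compounds than this note shows. Statements on the series, on what has been measured and on what is new or still open speak of the compounds shown alone.

In a functional assay on KB cells (Homo sapiens) for antiproliferative activity (on this read-out higher numbers stand for weaker inhibition and lower numbers for stronger inhibition), the three measured compounds stand as follows:
compound 1 `CSc1nc2c(C)nsc2n1[C@H]1C[C@H](O)[C@@H](CO)O1` — compound 1 gives > 100000 nM, a limit of the assay and not a number.
compound 2 `CSc1nc2c(C)nsc2n1[C@@H]1O[C@H](CO)[C@@H](O)[C@@H]1O` — compound 2 gives > 100000 nM, likewise a limit and not a number.
compound 3 `CSc1nc2cnsc2n1[C@@H]1O[C@H](CO)[C@@H](O)[C@@H]1O` — compound 3 gives > 100000 nM, again a limit and not a number.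

Compound 2 therefore stands only at a limit; no number places it within the set. The two steps that touch it are a step that the two limits leave unreadable from compound 1 to compound 2 and a step that the two limits leave unreadable from compound 2 to compound 3, and neither can be read in size because of the limit of > 100000 nM in this assay, at which 3 of the 3 values shown sit. Compound 4 `CSc1nc2c(C)nsc2n1[C@@H]1O[C@H](CO)[C@@H](O)[C@H]1O` is the next compound to be measured. Its difference from compound 2 is the two compounds have the same atoms and bonds and differ only in configuration as drawn: 1 of 4 stereo elements differ; a stereocentre at a saturated ring carbon is drawn S in compound 2 and R in compound 4. Among the measured compounds shown here, no measured step involves a change of configuration alone, so none bears directly on it, and the steps that are known give no readable size to build on. With every value shown sitting at the limit, the expectation for a number no higher from compound 2 to compound 4 (the limit leaves the size open) is a step of no readable size, most likely ending again at the limit. Compound 4 is accordingly estimated at 100000 nM, within 30000 nM to 300000 nM.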

Compound 4, half-maximal inhibitory concentration: > 100000 nM
Compound 4 gave a limit, no number (the forecaster's own chance of this, stated with the estimate: 80%); the middle value lies on the limit itself.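

Compound 4 sits at a limit in this assay, as do compound 1 and compound 2, so neither its step from compound 2 nor its step from compound 1 can be read in size: the limit of > 100000 nM in this assay, at which 4 of the 4 values shown sit.

The compounds shown leave open whether this change of configuration alone, or any other change among them, alters the read-out at all.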